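From 3-Chlorobenzyl to 4-Chlorobenzyl: An Expected Step

The source may report more compounds than this note shows. Statements on the series, on what has been measured and on what is new or still open speak of the compounds shown alone.

Of the compounds shown here, two have been measured so far. Compound 1 `COc1ccc(Cc2nc(N)c3nn(-c4ccccc4)cc3n2)cc1` carries a 4-methoxyphenyl on a saturated chain carbon bound to an aromatic carbon; in an assay on CHO cells for displacement of a labelled ligand from adenosine receptor A3 (Homo sapiens), read by scintillation counting, tested at 1 uM (a higher number here means more inhibition at the concentration tested (going by the name of the read-out), a lower number less inhibition), compound 1 gives 38%. Compound 2 `Nc1nc(Cc2cccc(Cl)c2)nc2cn(-c3ccccc3)nc12` carries 3-chlorophenyl at that same place, and in this assay compound 2 gives 42%. The step of a number 4 percentage points higher from compound 1 to compound 2 (within the scatter) is the only one in hand, and it stays inside the usual scatter, so compound 2 stands beside compound 1 with the two numbers not separable from each other.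

Compound 3 `Nc1nc(Cc2ccc(Cl)cc2)nc2cn(-c3ccccc3)nc12` has not yet been measured. It differs from compound 2 by 4-chlorophenyl in place of 3-chlorophenyl on a saturated chain carbon bound to an aromatic carbon. Among the compounds with values here, no measured step exchanges one chlorophenyl for another; the single step available, a number 4 percentage points higher from compound 1 to compound 2 (within the scatter), swapped the whole aryl group and still remained within the scatter. On that basis the step expected in this assay is a number 1 percentage points lower from compound 2 to compound 3 (within the scatter), that is, none beyond the scatter. Compound 3 is therefore estimated at 41% in this assay, with a range from 26% to 58%.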

Compound 3, a percentage reported as inhibition, at one concentration (the size of the read-out at that concentration, not a potency): 11%
Estimate against measurement, compound 3: 30 percentage points above, outside the stated range (below it).
By their numbers in this assay, from the lowest: compound 3; then compounds 1 and 2 (each within the scatter of the next).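

In this assay, the chlorine moving on the ring, from 3-chlorophenyl to 4-chlorophenyl on a saturated chain carbon bound to an aromatic carbon, gives a number 31 percentage points lower from compound 2 to compound 3 (beyond the scatter), although the two groups have the same atoms and the same counts. The earlier step, which exchanged the whole aryl group, stayed within the scatter, so it could not show that this place responds to where a single chlorine sits. Chloro in place of methoxy on an aromatic carbon gives a number 27 percentage points lower from compound 1 to compound 3 (beyond the scatter), so the 4-chlorophenyl stands apart from both the 4-methoxyphenyl and the 3-chlorophenyl, and nothing in the data at hand explains this difference.

The compounds shown leave open whether the loss belongs to chloro itself or to any group at that ring position, a question that a 4-fluorophenyl, a 4-methylphenyl or an unsubstituted phenyl on the same chain carbon would address. On these data alone, what a 3-methoxyphenyl would give in this assay also stays open, as does how these readings at one concentration would translate into potencies.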